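This account rests on a few compounds, and the source may have more. Where it says the series, first, only, none or still open, it means among the compounds named here.

Three close relatives of one core have been measured in a functional assay on HCT-116 cells (Homo sapiens) for cytotoxicity, read by MTT assay, with a stated time of 48 h (on this read-out higher numbers stand for weaker inhibition of growth and lower numbers for stronger inhibition of growth), and a fourth awaits its turn. Compound 1 `FC(F)(F)c1cccc(Cn2c(C(F)(F)F)nc3cc(Cl)c(Cl)cc32)c1` gives 50500 nM in this assay. Compound 2 `FC(F)(F)c1ccc(Cn2c(C(F)(F)F)nc3cc(Cl)c(Cl)cc32)cc1` carries the same atoms joined differently; the difference between the two cores is not broken down here, and in this assay compound 2 gives 19000 nM. Compound 3 `O=[N+]([O-])c1cccc(Cn2c(C(F)(F)F)nc3cc(Cl)c(Cl)cc32)c1` is compound 1 with one change, (nitro in place of trifluoromethyl on an aromatic carbon), and in this assay compound 3 gives 22800 nM. That change produced a 2.2-fold lower number from compound 1 to compound 3 (0.35 log units; beyond the scatter). Compound 2 and compound 3 lie within the scatter of each other, while compound 1 stands apart from both of them beyond it.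

Compound 4 `O=[N+]([O-])c1ccc(Cn2c(C(F)(F)F)nc3cc(Cl)c(Cl)cc32)cc1` is the not yet measured member. It is compound 2 with the change (nitro in place of trifluoromethyl on an aromatic carbon), the same kind of change as from compound 1 to compound 3, the surroundings differing only in that the group sits para to a large group rather than meta to a large group. Among the measured compounds shown here, compound 4 is expected to show a step of about a 1.7-fold lower number from compound 2 to compound 4 (0.24 log units; within the scatter), with some doubt because a 2.2-fold lower number from compound 1 to compound 3 (0.35 log units; beyond the scatter) is the single measured instance of this change and the place differs. In this assay compound 4 is therefore estimated at 11000 nM, expected to fall between 4000 nM and 30000 nM.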

Compound 4, concentration for 50% growth inhibition: 81600 nM
Beside the measured number, compound 4's estimate is 7.4-fold (0.87 log units) below it, outside the stated range (above it).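

With the group para to a large group, replacing trifluoromethyl by nitro gives a 4.3-fold higher number from compound 2 to compound 4 (0.63 log units; beyond the scatter) in this assay, which runs against the direction of the earlier step, a 2.2-fold lower number from compound 1 to compound 3 (0.35 log units; beyond the scatter). The change therefore cannot be carried from one core to the other in this series as a fixed step, since the two instances disagree in direction and the gap between them exceeds what repeated measurement would explain: the same change on two cores in this assay, a 2.2-fold lower number (0.35 log units; beyond the scatter) from compound 1 to compound 3 and a 4.3-fold higher number (0.63 log units; beyond the scatter) from compound 2 to compound 4, 9.5-fold (0.98 log units) apart, beyond the scatter of two such steps. Among the compounds shown here, this shows that the outcome of the change depends on the core that carries it, but with only one instance on each core it does not show why the two steps part, and it supports no general rule for the series.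

The compounds shown leave open whether other groups on the same aromatic ring, such as a nitrile, a methoxy group or an amine, would also respond differently on the two cores. They also leave open whether the opposite steps would persist if the two chlorines or the trifluoromethyl group on the shared core were replaced, for instance by hydrogen or a methyl group.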